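Inverting One More Stereocentre at a Saturated Chain Carbon

A few compounds are considered here, and "the series" means these few. Any claim that something is new, unique, unknown or untested is made for them only; others in the source may bear on it.

In a functional assay on P388 cells (Mus musculus) for cytotoxicity (a higher number here means a weaker inhibitor, a lower number a stronger inhibitor), compound 1 `C=C/C=C\[C@H](C)[C@H](OC(N)=O)[C@@H](C)[C@H](O)[C@@H](C)C[C@@](C)(O)[C@H]1[C@H](C)[C@@H](O)[C@@H](C)[C@@H]1/C=C/C[C@@H]1OC(=O)[C@H](C)[C@@H](O)[C@H]1C` gives 2420 nM and compound 2 `C=C/C=C\[C@H](C)[C@H](OC(N)=O)[C@@H](C)[C@H](O)[C@@H](C)C[C@](C)(O)[C@H]1[C@H](C)[C@@H](O)[C@@H](C)[C@@H]1/C=C/C[C@@H]1OC(=O)[C@H](C)[C@@H](O)[C@H]1C` gives 2090 nM so the two stand within the scatter of each other. For compound 3 `C=C/C=C\[C@H](C)[C@H](OC(N)=O)[C@@H](C)[C@H](O)[C@H](C)C[C@](C)(O)[C@H]1[C@H](C)[C@@H](O)[C@@H](C)[C@@H]1/C=C/C[C@@H]1OC(=O)[C@H](C)[C@@H](O)[C@H]1C` the change from compound 2 reads the two compounds have the same atoms and bonds and differ only in configuration as drawn: 1 of 17 stereo elements differ; a stereocentre at a saturated chain carbon is drawn S in compound 2 and R in compound 3 and no group is gained or lost. Within the data shown here, the only measured step bearing on it is a 1.2-fold lower number from compound 1 to compound 2 (0.06 log units; within the scatter) and it goes with the fact that compounds 1 and 2 differ only in the configuration as drawn at a different stereocentre. The estimated change is a 1.1-fold higher number from compound 2 to compound 3 (0.06 log units; within the scatter) and no step beyond the scatter is expected in this assay although a single inversion is thin support. Compound 3 is expected near 2400 nM with an estimated range from 1000 nM to 6500 nM for this measurement.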

Compound 3, half-maximal inhibitory concentration: 7650 nM
Compound 3: middle estimate off by 3.2-fold (0.50 log units), on the low side, and the stated range ends below it.
By their numbers in this assay, from the lowest: compounds 2 and 1 (each within the scatter of the next); then compound 3.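

In this assay, inverting this saturated chain carbon gives a 3.7-fold higher number from compound 2 to compound 3 (0.56 log units; beyond the scatter), so configuration here moves the number beyond the scatter, which the earlier inversion at the other stereocentre did not do. The step of a 3.2-fold higher number from compound 1 to compound 3 (0.50 log units; beyond the scatter) spans both inversions and also lies beyond the scatter. No group is gained or lost, so the shift rests on configuration alone: the fact that compounds 2 and 3 differ only in the configuration as drawn

Going by these compounds, whether this inversion acts the same with the other stereocentre drawn as in compound 1 stays open. So does what an ethyl group at this carbon would do.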